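Aryloxy swap on the shared core: compound 1 to compound 4

This account rests on a few compounds, and the source may have more. Where it says the series, first, only, none or still open, it means among the compounds named here.

Measured in a functional assay on SNB-19 cells (Homo sapiens) for inhibition, read by sulforhodamine B assay, with a stated time of 48 h; on this read-out lower numbers stand for stronger inhibition of growth and higher numbers for weaker inhibition of growth:
- compound 1 `Nc1cc(N)c2nc(-c3ccccc3)c(Oc3ccc(Cl)c(Cl)c3)nc2c1`: 52500 nM
- compound 3 `COc1cc(CNc2nc3cc(N)cc(N)c3nc2-c2ccccc2)cc(OC)c1OC`: 20900 nM
- compound 2 `CCOC(=O)[C@H](CCC(=O)O)NC(=O)c1ccc(CNc2nc3cc(N)cc(N)c3nc2-c2ccccc2)cc1`: reported only as a limit, < 100000 nM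

Among the two compounds with a number in this assay, compound 1 carries the higher one; compound 3 sits lower, beyond the scatter. Compound 2 sits at the limit of < 100000 nM in this assay, at which 1 of the 3 values shown sits, so it gives no number to compare.

Compound 4 `Nc1cc(N)c2nc(-c3ccccc3)c(Oc3ccc(F)cc3)nc2c1` differs from compound 1 by 4-fluorophenyl in place of 3,4-dichlorophenyl on an oxygen on an aromatic ring. Within the data shown here, no measured pair shows this change, so its size is open; a small step is expected, if anything towards a higher number. Compound 4 is therefore estimated at 70000 nM in this assay, within 30000 nM to 150000 nM, an expected step of a 1.3-fold higher number from compound 1 to compound 4 (0.12 log units; within the scatter).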

Compound 4, concentration for total growth inhibition: 33900 nM
The estimate for compound 4 lay 2.1-fold (0.31 log units) above the measured number; the measured number falls inside the stated range.
By their numbers in this assay, from the lowest: compounds 3, 4 and 1 (each within the scatter of the next, the first and the last beyond it).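

In this assay, among these compounds, 4-fluorophenyl in place of 3,4-dichlorophenyl on the oxygen gives a 1.5-fold lower number from compound 1 to compound 4 (0.19 log units; within the scatter) as the only measured step at this place. Growth inhibition on this read-out therefore does not depend on the two chlorines, as a fluorine-bearing aryl group serves within the scatter. Nothing at hand bears on a cause for this step.

Going by these compounds, whether an amine, a carboxylic acid or a longer chain in place of the 4-fluorophenyl on this oxygen would shift the number stays open. One pair sets no trend.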